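Removing the Aromatic Chlorine from Compound 1

This account rests on a few compounds, and the source may have more. Where it says the series, first, only, none or still open, it means among the compounds named here.

Going by the values given here, compound 1 `O=c1c(CSC(=S)N2CCOCC2)coc2cc(Cl)ccc12` is one of two compounds measured in a functional assay on MDA-MB-435S cells (Homo sapiens) for antiproliferative activity, read by MTT assay, with a stated time of 72 h (on this read-out lower numbers stand for stronger inhibition and higher numbers for weaker inhibition), where compound 1 gives 600 nM, the highest of the two numbers. Its partner, compound 2 `O=c1c(CSC(=S)N2CCCCC2)coc2cc(Cl)ccc12`, gives 240 nM; the step of a 2.5-fold lower number from compound 1 to compound 2 (0.40 log units; beyond the scatter) comes from a change at the thiocarbonyl carbon, not at the aromatic ring. Compound 3 `O=c1c(CSC(=S)N2CCOCC2)coc2ccccc12` differs from compound 1 by hydrogen in place of chloro on an aromatic carbon. Among the compounds with values here, no measured step touches this position, so no direct precedent exists. The expected outcome for compound 3 is a step of a 1.5-fold higher number from compound 1 to compound 3 (0.18 log units; within the scatter), likely small. Compound 3 is therefore estimated at 900 nM, within 300 nM to 2700 nM.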

Compound 3, half-maximal inhibitory concentration: 3900 nM
Compound 3: the middle estimate sits 4.3-fold (0.64 log units) below what was measured; measured number outside the range, above it.
By their numbers in this assay, from the lowest: compound 2; then compound 1; then compound 3.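

In this assay, the chloro on the aromatic carbon clearly counts: hydrogen in its place gives a 6.5-fold higher number from compound 1 to compound 3 (0.81 log units; beyond the scatter). Going by these compounds alone, until now, the only step read was at the thiocarbonyl carbon, so this is the first sign that the aromatic ring of the shared core also affects the number. No measurement shown here explains the loss.

From the compounds shown here alone, whether another group on this carbon, such as fluoro, bromo, methoxy or an amine, would match chloro remains open. So does whether removing chloro from compound 2 would give a similar step.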